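A few compounds are considered here, and "the series" means these few. Any claim that something is new, unique, unknown or untested is made for them only; others in the source may bear on it.

Measured so far in an ADME assay on Vero cells (Chlorocebus sabaeus) for cytotoxicity, read by MTT assay, with a stated time of 72 h; a lower number here means that less compound is tolerated, a higher number that more compound is tolerated:
- compound 1 `COc1c(N2CCN(CN3C(=O)/C(=N\O)c4ccccc43)CC2)c(F)cc2c(=O)c(C(=O)O)cn(C3CC3)c12` at 74400 nM
- compound 2 `CO/N=C1\C(=O)N(CN2CCN(c3c(F)cc4c(=O)c(C(=O)O)cn(C5CC5)c4c3OC)CC2)c2ccccc21` at 76500 nM

Compound 2 stands at 76500 nM in this assay and so lies level with compound 1 within the scatter. Compound 3 `CCO/N=C1\C(=O)N(CN2CCN(c3c(F)cc4c(=O)c(C(=O)O)cn(C5CC5)c4c3OC)CC2)c2ccccc21` differs from compound 2 by a single change methyl in place of hydrogen on a saturated chain carbon bound to an oxygen on an unsaturated carbon in which methoxy becomes ethoxy, with methyl in place of hydrogen on a saturated chain carbon bound to an oxygen on an unsaturated carbon. Among the compounds with values here, only one measured step bears on this, a 1.0-fold higher number from compound 1 to compound 2 (0.01 log units; within the scatter) for a methyl in place of hydrogen on an oxygen, and it lies within the scatter. That methyl stands at a different place, so the support is thin. The step expected in this assay is a 1.0-fold lower number from compound 2 to compound 3 (0.00 log units; within the scatter) in size, with no direction favoured and nothing beyond the scatter. For compound 3 the estimate is 76000 nM with an expected range from 45000 nM to 125000 nM in this measure.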

Compound 3, half-maximal cytotoxic concentration: 91500 nM
For compound 3 the middle estimate is 1.2-fold (0.08 log units) below the measured one, and the stated range covers the measured number.
By their numbers in this assay, from the lowest: compounds 1, 2 and 3 (each within the scatter of the next).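

In this assay, the change from methoxy to ethoxy gives a 1.2-fold higher number from compound 2 to compound 3 (0.08 log units; within the scatter), so a methyl on a saturated chain carbon bound to an oxygen on an unsaturated carbon leaves the number within the scatter. The full replacement of the hydrogen on that oxygen by ethyl gives a 1.2-fold higher number from compound 1 to compound 3 (0.09 log units; within the scatter), which shows that the result seen earlier for methyl also holds for this ethyl group, with compounds 1, 2 and 3 all level within the scatter. No measurement is available to explain this flat result.

From the compounds shown here alone, what a longer chain, a benzyl group or an amine would do at this place stays open. The compounds shown differ only at this one place, so they cannot tell how far the shared core contributes to the number.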